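This account rests on a few compounds, and the source may have more. Where it says the series, first, only, none or still open, it means among the compounds named here.

Measured compounds in a functional assay on U-937 cells (Homo sapiens) for cytotoxicity, read by CCK-8 assay, with a stated time of 72 h; on this read-out higher numbers stand for weaker inhibition and lower numbers for stronger inhibition:
compound 1 `C=CCn1c(=O)/c(=C\c2cccc(F)c2)[nH]c(=O)/c1=C\c1ccccc1OC` gives 2500 nM
compound 2 `C=CCn1c(=O)/c(=C\c2cccc(Cl)c2Cl)[nH]c(=O)/c1=C\c1ccccc1OC` gives 500 nM

Compound 2 holds the lowest of the two numbers in this assay; its nearest neighbour is compound 1, and the step of a 5.0-fold lower number from compound 1 to compound 2 (0.70 log units; beyond the scatter) lies beyond the scatter. Compound 3 `C=CCn1c(=O)/c(=C\c2cc(Br)ccc2F)[nH]c(=O)/c1=C\c1ccccc1OC` is not yet measured. The change is 5-bromo-2-fluorophenyl in place of 2,3-dichlorophenyl on a double-bonded chain carbon bound to an aromatic carbon. Going by the values given here, the only measured step at this place, a 5.0-fold lower number from compound 1 to compound 2 (0.70 log units; beyond the scatter), concerns a different exchange of halogenated phenyl groups and therefore bears only loosely on the new change; it shows that the group at this place can move the number by a modest amount, but gives no direct guide to the direction here. On that basis the expected step from compound 2 to compound 3 in this assay is a 2.0-fold higher number from compound 2 to compound 3 (0.30 log units; within the scatter), with the direction uncertain. Compound 3 is estimated at 1000 nM in this assay, within a range from 300 nM to 3500 nM.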

Compound 3, half-maximal inhibitory concentration: 4700 nM
For compound 3 the middle estimate is 4.7-fold (0.67 log units) below the measured one; the measured number lies above the stated range.
By their numbers in this assay, from the lowest: compound 2; then compounds 1 and 3 (each within the scatter of the next).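

In this assay the step of a 9.4-fold higher number from compound 2 to compound 3 (0.97 log units; beyond the scatter) shows that this place responds strongly to the halogen pattern on the phenyl group, even though 2,3-dichlorophenyl and 5-bromo-2-fluorophenyl have the same heavy-atom count and the same hydrogen-bond counts. The step of a 1.9-fold higher number from compound 1 to compound 3 (0.27 log units; within the scatter) keeps compound 1 and compound 3 within the scatter of each other despite their different halogen patterns, so among these three compounds only the 2,3-dichlorophenyl group of compound 2 stands apart. Nothing measured here explains this difference.

On these data alone, whether the lower number of compound 2 needs both chlorines or only one of them remains open. So does how an aminophenyl or a carboxyphenyl group, which carries no halogen, would behave at this place.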